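This account rests on a few compounds, and the source may have more. Where it says the series, first, only, none or still open, it means among the compounds named here.

Working notes on the series. Going by the values given here, compound 1 `Cc1ccc(C)c(-n2nncc2CN2C(=O)C3(C(C#N)=C(N)Oc4c3c3nc5ccccc5nc3c3ccccc43)c3ccccc32)c1` and compound 2 `CC(=O)Nc1ccc(-n2nncc2CN2C(=O)C3(C(C#N)=C(N)Oc4c(N)cc5nc6ccccc6nc5c43)c3ccccc32)cc1` are the two measured members, each carrying an aryl group on an aromatic nitrogen of the shared core. In a functional assay on HCT-116 cells (Homo sapiens) for antiproliferative activity, read by MTT assay, with a stated time of 48 h (a higher number here means a weaker inhibitor, a lower number a stronger inhibitor), compound 1 gives > 50000 nM, which is a limit of the assay and not a number. In this assay compound 2 likewise gives > 50000 nM, again a limit. Compound 2 thus stands at the limit of > 50000 nM in this assay, at which 2 of the 2 values shown sit, so no measured step can be read from these two. Compound 3 `COc1cc(-n2nncc2CN2C(=O)C3(C(C#N)=C(N)Oc4c(N)cc5nc6ccccc6nc5c43)c3ccccc32)c(OC)cc1Cl` is not yet measured; it differs from compound 2 in one place (4-chloro-2,5-dimethoxyphenyl in place of 4-acetamidophenyl on an aromatic nitrogen). With both measured compounds sitting at the limit, the expected step that the limit leaves unreadable from compound 2 to compound 3 is taken as none beyond the scatter, in no fixed direction. For compound 3 in this assay the expected value is 60000 nM, with a range from 20000 nM to 200000 nM, and a limit rather than a number is the likelier report.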

Compound 3, half-maximal inhibitory concentration: > 50000 nM
Compound 3: only a limit was reported; the forecaster's own chance of this, stated with the estimate: 75%; the middle value is on the limit's open side.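

Compound 3 gives no readable step from compound 2, as both values are limits of the assay and not numbers, in this assay: the limit of > 50000 nM in this assay, at which 3 of the 3 values shown sit.

The compounds shown leave open whether 4-chloro-2,5-dimethoxyphenyl and 4-acetamidophenyl differ at all in their effect on antiproliferative activity.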